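From 3,3-dimethylbutyl to 4-phenylbut-1-yn-1-yl

A few compounds are considered here, and "the series" means these few. Any claim that something is new, unique, unknown or untested is made for them only; others in the source may bear on it.

Among the measured compounds shown here, in a functional assay on NIH3T3 cells (Mus musculus) (a lower number here means that less compound is needed, a higher number that more compound is needed for the effect), compound 3 `Cn1cncc1C(OCc1ccc(C#N)cc1CCC(C)(C)C)c1ccc(C#N)cc1` gives 0.54 nM, the lowest readable number so far. Compound 1 `Cn1cncc1C(OCc1ccc(C#N)cc1/C=C/c1ccccn1)c1ccc(C#N)cc1` gives 23.1 nM. Compound 2 `Cn1cncc1C(OCc1ccc(C#N)cc1C#Cc1cccc(O)c1)c1ccc(C#N)cc1` is reported as a limit, > 0.1 nM, so its 2-(3-hydroxyphenyl)ethynyl group gives no readable step. Compound 4 `Cn1cncc1C(OCc1ccc(C#N)cc1C#CCCc1ccccc1)c1ccc(C#N)cc1` carries 4-phenylbut-1-yn-1-yl in place of 3,3-dimethylbutyl on the aromatic carbon: 4-phenylbut-1-yn-1-yl in place of 3,3-dimethylbutyl on an aromatic carbon. For the measured compounds named here, the one readable step bearing on this is a 43-fold lower number from compound 1 to compound 3 (1.63 log units; beyond the scatter), which exchanged the ring-bearing 2-(pyridin-2-yl)ethenyl for 3,3-dimethylbutyl. A partial return toward a higher number is therefore expected in this assay, smaller than that step, and the estimate is a 3.7-fold higher number from compound 3 to compound 4 (0.57 log units; beyond the scatter). Compound 4 is expected at 2 nM, with an estimated range of 0.3 nM to 12 nM.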

Compound 4, half-maximal effective concentration: 130 nM
The estimate for compound 4 lay 65-fold (1.81 log units) below the measured number; the measured number lies above the stated range.
By their numbers in this assay, from the lowest: compound 3; then compound 1; then compound 4.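

At this position, on an aromatic carbon meta to a cyano group, this assay separates the two chains sharply: 4-phenylbut-1-yn-1-yl in place of 3,3-dimethylbutyl gives a 240-fold higher number from compound 3 to compound 4 (2.38 log units; beyond the scatter). The ring-bearing 2-(pyridin-2-yl)ethenyl does not mark the top of the range either, with a 5.6-fold higher number from compound 1 to compound 4 (0.75 log units; beyond the scatter). The steps involving compound 2 cannot be read, since its value is a limit: the limit of > 0.1 nM in this assay, at which 1 of the 4 values shown sits.

The compounds shown do not separate the phenyl ring from the triple bond in this rise. A saturated 4-phenylbutyl chain would part the two.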